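This account rests on a few compounds, and the source may have more. Where it says the series, first, only, none or still open, it means among the compounds named here.

Compound 1 `COc1cc(NC(=O)/C=C/c2cccc(OCc3ccccc3)c2)cc(OC)c1OC`: 3600 nM
Compound 2 `C=C(Br)C(=O)Nc1cccc(/C=C/C(=O)Nc2ccc(F)c(F)c2)c1`: 8700 nM
Compound 3 `C=C(Br)C(=O)Nc1cccc(/C=C/C(=O)NCc2ccc(C)cc2)c1`: 2700 nM

All three numbers come from a functional assay on HT-29 cells (Homo sapiens) for inhibition, read by MTT assay, with a stated time of 72 h; a higher number here means a weaker inhibitor, a lower number a stronger inhibitor. Compound 1 cannot be told apart from compound 3, because their values lie within the usual scatter of each other, while the number for compound 1 is lower than that for compound 2.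

Compound 4 `C=C(Br)C(=O)Nc1cccc(/C=C/C(=O)Nc2cc(OC)c(OC)c(OC)c2)c1` has not yet been measured. It differs from compound 1 in one place: ((1-bromoethenyl)carbonyl)amino in place of benzyloxy on an aromatic carbon. It therefore carries the ((1-bromoethenyl)carbonyl)amino of compound 2 and compound 3, while keeping the group on the amide-type nitrogen of compound 1.

Going by the values given here, no measured step makes this swap directly. Among the compounds with values here, the only measured step, a 3.2-fold lower number from compound 2 to compound 3 (0.51 log units; beyond the scatter), changes the group on the amide-type nitrogen instead, so it bears on the question only indirectly. It shows a modest shift among compounds that carry the incoming group. Compound 3, at 2700 nM, sits within the scatter of compound 1, at 3600 nM, which suggests no direction. Compound 2, at 8700 nM, keeps the upper end of the range open. No step beyond the scatter is therefore expected in this assay. The expected step is a 1.2-fold lower number from compound 1 to compound 4 (0.08 log units; within the scatter). For compound 4 the estimated value is 3000 nM, with an expected range from 900 nM to 9000 nM.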

Compound 4, half-maximal inhibitory concentration: 2300 nM
Compound 4: middle estimate off by 1.3-fold (0.12 log units), on the high side, within the range that was stated.
By their numbers in this assay, from the lowest: compounds 4, 3 and 1 (each within the scatter of the next); then compound 2.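

In this assay, going by these compounds alone, replacing benzyloxy with ((1-bromoethenyl)carbonyl)amino on an aromatic carbon, meta to a large group, gives a 1.6-fold lower number from compound 1 to compound 4 (0.19 log units; within the scatter), which is the first direct reading of this swap. The two groups are built quite differently: benzyloxy carries a six-membered aromatic ring and no hydrogen-bond donor, whereas the incoming group has no ring and does carry a hydrogen-bond donor, yet this difference leaves the number within the scatter when the group on the amide-type nitrogen of compound 1 stays in place. Nothing measured here accounts for the two groups reading alike in these cells.

The compounds shown cannot say whether the bromine of the incoming group matters, since a plain acetylamino group or a simple amino group at this place would be needed to separate the bromoethenyl part from the amide link. They also leave open whether benzyloxy and ((1-bromoethenyl)carbonyl)amino would still read alike alongside a 4-methylbenzyl or 3,4-difluorophenyl group on the amide-type nitrogen.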